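The source may report more compounds than this note shows. Statements on the series, on what has been measured and on what is new or still open speak of the compounds shown alone.

Measured so far:
compound 1 `Cc1nc(-c2ccccc2)n2c(S)nncc12`: > 48000 nM
compound 2 `CCOC(=O)CSc1nncc2c(C)nc(C)n12`: > 48000 nM

Compound 1 `Cc1nc(-c2ccccc2)n2c(S)nncc12` was examined in a functional assay for inhibition, with Homo sapiens as the target; on this read-out higher numbers stand for weaker inhibition and lower numbers for stronger inhibition. In this assay compound 1 gives > 48000 nM, which is a limit of the assay and not a number. Compound 2 `CCOC(=O)CSc1nncc2c(C)nc(C)n12` gives > 48000 nM in this assay, again a limit rather than a number. Both results sit at the limit of > 48000 nM in this assay, at which 2 of the 2 values shown sit, so compound 1 can be placed neither above nor below compound 2, and neither compound shows inhibition within the range the assay can report.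

Compound 3 `Cc1nc(-c2ccccc2)n2c(O)nncc12` has not yet been measured. It differs from compound 1 in one place: hydroxy in place of sulfanyl on an aromatic carbon. For the measured compounds named here, no step between measured compounds is available, and the two values on hand are both limits. The expected step that the limit leaves unreadable from compound 1 to compound 3 is within the scatter, with no direction. Compound 3 is therefore estimated at 60000 nM, with a range from 20000 nM to 200000 nM, and most likely will again be reported only as a limit.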

Compound 3, half-maximal inhibitory concentration: > 48000 nM
Compound 3: a limit, no number (the forecaster's own chance of this, stated with the estimate: 80%); the middle value is on the limit's open side.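

No step can be read from compound 1 to compound 3 in this assay, as both results are limits of the assay and not numbers: the limit of > 48000 nM in this assay, at which 3 of the 3 values shown sit.

The compounds shown leave open whether exchanging sulfanyl for hydroxy changes inhibition at all, and whether any compound on this core gives a readable number.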